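The compounds below may be only part of what the source reports. "The series", "measured", "known", "first", "only" and "open" are said of these compounds alone.

Compound 1 `O=c1[nH]c(=O)n([C@@H]2O[C@H](CO)[C@@H](O)[C@H]2O)c(I)c1F`: > 50000 nM
Compound 2 `CCc1c(F)c(=O)[nH]c(=O)n1[C@@H]1O[C@H](CO)[C@@H](O)[C@H]1O`: 1900 nM

Both were tested in a functional assay on OCI-Ly7 cells (Homo sapiens) for antiproliferative activity, read by WST assay, with a stated time of 3 days; a higher number here means a weaker inhibitor, a lower number a stronger inhibitor. For compound 1, > 50000 nM is a limit of the assay and not a number. Among the measured compounds shown here, compound 2, at 1900 nM, therefore holds the only true number so far. Compound 3 `O=Cc1c(F)c(=O)[nH]c(=O)n1[C@@H]1O[C@H](CO)[C@@H](O)[C@H]1O` carries formyl in place of ethyl on an aromatic carbon. For the measured compounds named here, the sole measured step at that carbon is large: an at least 26-fold lower number from compound 1 to compound 2 (1.42 log units; beyond the scatter). Its starting point is the limit of > 50000 nM in this assay, at which 1 of the 2 values shown sits. Since that step shows this carbon can shift the number strongly, and ethyl is now leaving, a higher number is expected, an estimated 3.2-fold higher number from compound 2 to compound 3 (0.50 log units; beyond the scatter). Compound 3 is estimated at 6000 nM, with an expected range of 700 nM to 50000 nM.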

Compound 3, half-maximal inhibitory concentration: 600 nM
For compound 3 the middle estimate is 10-fold (1.00 log units) above the measured one; the measured number lies below the stated range.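

In this assay, formyl in place of ethyl moves the number further down, a 3.2-fold lower number from compound 2 to compound 3 (0.50 log units; beyond the scatter), so at this carbon the activity does not rest on ethyl alone. Both groups have 2 heavy atoms, yet the step lies beyond the scatter, so heavy-atom count alone does not set the number here. The step from iodo reads an at least 83-fold lower number from compound 1 to compound 3 (1.92 log units; beyond the scatter), and its size is only a bound, set by a limit of the assay and not by a number: the limit of > 50000 nM in this assay, at which 1 of the 3 values shown sits.

The compounds shown leave open how a hydroxymethyl, a carboxylic acid or an amine would fare at this carbon. They also leave open whether a chain longer than ethyl would be tolerated.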